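A few compounds are considered here, and "the series" means these few. Any claim that something is new, unique, unknown or untested is made for them only; others in the source may bear on it.

Working notes on the series.

Compound 1 `CC(C)c1c(C(=O)NCc2cccc(F)c2F)nn(-c2ccc(F)cc2)c1OC[C@@H](O)C[C@@H](O)CC(=O)O` is the reference point. Within the data shown here, in an assay on microsomes from liver for inhibition of 3-hydroxy-3-methylglutaryl-coenzyme A reductase (Rattus norvegicus) (a lower number here means a stronger inhibitor, a higher number a weaker inhibitor), compound 1 gives 2 nM, the lowest of the three numbers measured so far. Compound 2 `CC(C)c1c(C(=O)N2CCCC2c2ccccc2)nn(-c2ccc(F)cc2)c1OC[C@@H](O)C[C@@H](O)CC(=O)O` gives 14 nM in this assay, and compound 3 `CC(C)c1c(C(=O)N2CCCCC2)nn(-c2ccc(F)cc2)c1OC[C@@H](O)C[C@@H](O)CC(=O)O` gives 47 nM. The two measured steps away from compound 1 both replace the whole (2,3-difluorobenzyl)amino group on the carbonyl carbon with a cyclic amine: a 7.0-fold higher number from compound 1 to compound 2 (0.85 log units; beyond the scatter) and a 24-fold higher number from compound 1 to compound 3 (1.37 log units; beyond the scatter). Between the two cyclic amines, a 3.4-fold higher number from compound 2 to compound 3 (0.53 log units; beyond the scatter).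

Compound 4 `CC(C)c1c(C(=O)NCc2ccc(Cl)cc2)nn(-c2ccc(F)cc2)c1OC[C@@H](O)C[C@@H](O)CC(=O)O` keeps the benzylamide and alters only the aryl substitution: 4-chlorophenyl in place of 2,3-difluorophenyl on a saturated chain carbon bound to an amide-type nitrogen. Among the measured compounds shown here, no measured step changes the substituent pattern of this aryl ring; the steps from compound 1 to compound 2 and from compound 1 to compound 3 show only that removing the benzylamino group altogether costs potency, from modest to large. They therefore bear on the change only indirectly: they indicate that the benzylamide itself carries much of the activity of compound 1, and that compound 4, which retains it, should stay nearer to compound 1 than compounds 2 and 3 do. A small step in this assay, likely toward a somewhat higher number, is expected for compound 4, of the order of a 2.0-fold higher number from compound 1 to compound 4 (0.30 log units; within the scatter). The expected value for compound 4 in this assay is 4 nM, with a range from 1.5 nM to 12 nM.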

Compound 4, half-maximal inhibitory concentration: 6.7 nM
The estimate for compound 4 lay 1.7-fold (0.22 log units) below the measured number; measured number inside the range.
By their numbers in this assay, from the lowest: compound 1; then compound 4; then compound 2; then compound 3.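

In this assay, among these compounds, the step from 2,3-difluorophenyl to 4-chlorophenyl on a saturated chain carbon bound to an amide-type nitrogen gives the first direct reading of this aryl group, with the benzylamide kept: a 3.4-fold higher number from compound 1 to compound 4 (0.53 log units; beyond the scatter) shows that the substitution pattern on this ring matters on its own, even though the change is far smaller than the loss on going from compound 1 to compound 3. The (4-chlorobenzyl)amino group also remains better than both cyclic amines on the carbonyl carbon, with a 7.0-fold lower number from compound 3 to compound 4 (0.85 log units; beyond the scatter) and a 2.1-fold lower number from compound 2 to compound 4 (0.32 log units; beyond the scatter), so the lead over these amines is not confined to the 2,3-difluorobenzyl group of compound 1, though the margin over the 2-phenylpyrrolidin-1-yl group of compound 2 is narrow. The compounds shown offer no measurement that accounts for the size of these steps.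

Compound 4 differs from compound 1 in both the halogen and its place on the ring, so these two changes cannot be separated here. Unsubstituted benzyl, 4-fluorobenzyl and 2,3-dichlorobenzyl on the same amide nitrogen would each bear on that question, and the effect of a longer chain between the amide nitrogen and the aryl ring also remains open.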